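A few compounds are considered here, and "the series" means these few. Any claim that something is new, unique, unknown or untested is made for them only; others in the source may bear on it.

Compound 1, `CNC(=O)c1cc(C(=O)NC2CC2)cn(Cc2cccc(OC)c2)c1=O`, gives 3.
Compound 2, `CNC(=O)c1cc(C(=O)NCCCC2CNCCO2)cn(Cc2ccccc2)c1=O`, gives 1.4.
Compound 3, `CNC(=O)c1cc(C(=O)NC2CC2)c(C)n(Cc2ccccc2)c1=O`, gives 2.9.

All three numbers come from a physicochemical assay for lipophilicity, at pH 7.4; a lower number here means a more polar compound, a higher number a more lipophilic compound. Compound 1 stands at the top of the three. Compound 3 lies within the usual scatter of compound 1, so the two cannot be told apart, whereas compound 2 sits clearly lower, beyond the scatter. The measured compounds differ from one another in more than one place, so no single step can be read off among them.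

Compound 4, `CNC(=O)c1cc(C(=O)NC2CC2)cn(Cc2ccc3nc[nH]c3c2)c1=O`, is still to be measured in this assay. It arises from compound 1 by one change: 1H-benzimidazol-6-yl in place of 3-methoxyphenyl on a saturated chain carbon bound to an aromatic nitrogen. The entering ring system, as counted there, brings hetero atoms and a hydrogen-bond donor that the leaving group did not have. Compound 2, with its value of 1.4, shows that a substituent richer in hetero atoms can pull the number down well beyond the scatter. A downward step is therefore expected here, larger than the scatter but smaller than the gap to compound 2. Compound 4 is expected to come out near 1.8, in a range from 1.3 to 2.4. The expected step is then a number 1.20 log units lower from compound 1 to compound 4 (beyond the scatter).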

Compound 4, distribution coefficient: 1.2
Beside the measured number, compound 4's estimate is 0.60 log units above it, and the stated range ends above it.
By their numbers in this assay, from the lowest: compounds 4 and 2 (each within the scatter of the next); then compounds 3 and 1 (each within the scatter of the next).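

In this assay the exchange of 3-methoxyphenyl for 1H-benzimidazol-6-yl, on a saturated chain carbon bound to an aromatic nitrogen, gives a number 1.80 log units lower from compound 1 to compound 4 (beyond the scatter) and counts as a large step. The earlier compounds shown here differed from one another in more than one place, so none of them could show what a single place does; here the rest of compound 1 stays unchanged, and this one position alone moves the number well beyond the scatter. The entering group differs from the leaving one in holding a five-membered aromatic ring with 2 hetero atoms and 1 hydrogen-bond donor, yet no measurement shown here tells which of these features matters or explains why the number moved.

Still open, on these data alone, is whether a simpler group at the same place, such as an indole, or an amine or a carboxylic acid in place of the methoxy of 3-methoxyphenyl, would give a step of similar size. Also open, as far as these compounds go, is whether this same exchange would give a similar step on the core of compound 3.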